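A few compounds are considered here, and "the series" means these few. Any claim that something is new, unique, unknown or untested is made for them only; others in the source may bear on it.

Among the measured compounds shown here, in an ADME assay on Vero 76 cells (Chlorocebus sabaeus) for cytotoxicity, read by microscopy (on this read-out lower numbers stand for higher toxicity in this test and higher numbers for lower toxicity in this test), compound 2 `O[C@@H]1[C@H](O)[C@@H]2C[C@@H]2[C@H]1n1cnc2c(NC(C3CCC3)C3CCC3)nc(Cl)nc21` gives 16000 nM and holds the only actual number so far. Compound 1 `O[C@@H]1[C@H](O)[C@@H]2C[C@@H]2[C@H]1n1cnc2c(NCC(C3CC3)C3CC3)nc(Cl)nc21` is reported only as a limit (> 50000 nM). Compound 3 `O[C@@H]1[C@H](O)[C@@H]2C[C@@H]2[C@H]1n1cnc2c(NCc3ccccc3F)nc(Cl)nc21` differs from compound 2 on a nitrogen on an aromatic ring: 2-fluorobenzyl in place of dicyclobutylmethyl on a nitrogen on an aromatic ring. For the measured compounds named here, one measured step bears on this place: an at least 3.1-fold lower number from compound 1 to compound 2 (0.49 log units; beyond the scatter). Going by the values given here, no measured step tests 2-fluorobenzyl, so only a small move toward a higher number in this assay is expected (estimated: a 2.3-fold higher number from compound 2 to compound 3 (0.35 log units; beyond the scatter)). For compound 3 the expected value is 36000 nM, with an estimated range from 14000 nM to 50000 nM.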

Compound 3, half-maximal cytotoxic concentration: > 50000 nM
Compound 3 was reported as a limit (the forecaster's own chance of this, stated with the estimate: 45%); at least 1.3-fold (0.14 log units) between middle value and limit.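

In this assay, the change to 2-fluorobenzyl gives an at least 3.1-fold higher number from compound 2 to compound 3 (0.49 log units; beyond the scatter), so compound 2, with dicyclobutylmethyl, now has a lower number than both other compounds. Compound 3 gives > 50000 nM, which is a limit of the assay. The step between compound 1 and compound 3 cannot be read, because both values are limits: the limit of > 50000 nM in this assay, at which 2 of the 3 values shown sit.

On these data alone, the true size of the step to compound 3 remains open. As far as these compounds go, it is also open whether an unsubstituted benzyl or a longer chain bearing an amine at this place would give a readable number.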